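The source may report more compounds than this note shows. Statements on the series, on what has been measured and on what is new or still open speak of the compounds shown alone.

Compound 1 `CC(=O)Oc1ccc(C(=O)Nc2cc3ccc(OCC4CCCNC4)c(C)c3oc2=O)cc1CC=C(C)C` gives 620 nM in a functional assay on SK-BR-3 cells (Homo sapiens) for antiproliferative activity; a lower number here means a stronger inhibitor, a higher number a weaker inhibitor. Compound 2 `CC(C)=CCc1cc(C(=O)Nc2cc3ccc(OCCCNC(C)C)c(C)c3oc2=O)ccc1O` gives 750 nM in this assay.

Only these two numbers are known, and compound 2 and compound 1 lie within the usual scatter of each other, so the two compounds cannot be separated on these numbers. Compound 3 `CC(C)=CCc1cc(C(=O)Nc2cc3ccc(OCCCN(C)Cc4ccccc4)c(C)c3oc2=O)ccc1O` differs from compound 2 in one place: benzyl(methyl)amino in place of isopropylamino on a saturated chain carbon, three bonds along the chain from an oxygen on an aromatic ring. Among the measured compounds shown here, no measured pair shows this change, so its effect is unknown from the data. A step of modest size is expected, as a 1.2-fold higher number from compound 2 to compound 3 (0.08 log units; within the scatter), and it may not exceed the scatter. Compound 3 is estimated at 900 nM, within a range from 300 nM to 3000 nM.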

Compound 3, half-maximal inhibitory concentration: 10700 nM
Compound 3: the middle estimate sits 12-fold (1.08 log units) below what was measured, and the stated range ends below it.
By their numbers in this assay, from the lowest: compounds 1 and 2 (each within the scatter of the next); then compound 3.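

Placing benzyl(methyl)amino on this chain in place of isopropylamino gives a 14-fold higher number from compound 2 to compound 3 (1.15 log units; beyond the scatter) in this assay, so the amine at this place matters strongly, which compound 1 and compound 2 could not show. The change is not a single one: the entering group adds a six-membered aromatic ring and has no hydrogen-bond donor, while the leaving group has one. Nothing measured here explains the loss of activity. Still open, on these data alone, is whether benzylamino, which keeps the amine hydrogen, or dimethylamino, which has no ring, would stay close to compound 2.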